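The compounds below may be only part of what the source reports. "The series", "measured", "known", "first", "only" and "open" are said of these compounds alone.

Compound 1 `C=C1C[C@]23C[C@@]1(O)CC[C@@H]2c1cccc(C)c1[C@@H]3Cn1cc(-c2ccc(Cl)cc2)nn1`: in a functional assay on MCF7 cells (Homo sapiens) for cytotoxicity, read by MTT assay, with a stated time of 4 days (a lower number here means a stronger inhibitor, a higher number a weaker inhibitor), compound 1 gives > 20000 nM, which is a limit of the assay, not a number.
Compound 2 `C=C1C[C@]23C[C@@]1(O)CC[C@@H]2c1cccc(C)c1[C@@H]3Cn1cc(-c2ccc(C)cc2)nn1`: in this assay compound 2 gives > 20000 nM, again a limit of the assay.
Compound 3 `C=C1C[C@]23C[C@@]1(O)CC[C@H]2c1cc(Br)c(O)c(C)c1[C@@H]3Cn1cc(-c2ccc(C)cc2)nn1`: in this assay compound 3 gives > 20000 nM, also a limit of the assay.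

Compound 2 and compound 1 differ by one change, (chloro in place of methyl on an aromatic carbon). The step that the two limits leave unreadable from compound 2 to compound 1 cannot be sized, because of the limit of > 20000 nM in this assay, at which 3 of the 3 values shown sit. How the core of compound 3 differs from that of compound 2 is not broken down here.

Compound 4 `C=C1C[C@]23C[C@@]1(O)CC[C@H]2c1cc(Br)c(O)c(C)c1[C@@H]3Cn1cc(-c2ccc(Cl)cc2)nn1` has not yet been measured in this assay. It differs from compound 3 by chloro in place of methyl on an aromatic carbon, the same change as from compound 2 to compound 1, made on the same kind of place. Since compound 3 sits at the limit and the earlier step gave no readable size, the expectation for compound 4 is also a limit; the step that the limit leaves unreadable from compound 3 to compound 4 is expected to be essentially nothing. Compound 4 is estimated at 30000 nM, with a range from 10000 nM to 100000 nM.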

Compound 4, half-maximal inhibitory concentration: 10200 nM
For compound 4 the middle estimate is 2.9-fold (0.47 log units) above the measured one, and the stated range covers the measured number.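

In this assay, changing 4-methylphenyl to 4-chlorophenyl on the core of compound 3 gives an at least 1.9-fold lower number from compound 3 to compound 4 (0.29 log units; that floor lies within the scatter). The same change on the core of compound 2 cannot be read, and the two cores cannot be compared for the size of this change, because both ends of that earlier step sit at a limit of the assay: the limit of > 20000 nM in this assay, at which 3 of the 4 values shown sit. Compound 4 alone carries a measured number, so this pair shows that a readable value can appear after the change on one core, but with the floor of the step inside the usual scatter, it does not establish a real difference, nor does it show that the change carries from one core to the other.

Still open, from the compounds shown here alone, is whether another group at the same place on the ring, such as an amine, a carboxylic acid or a longer chain, would give a readable number on either core. Also open, going by these compounds, is which part of the difference between the two cores matters for the values seen here.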